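Compound 3: a longer arm on the shared core

The source may report more compounds than this note shows. Statements on the series, on what has been measured and on what is new or still open speak of the compounds shown alone.

Among the compounds with values here, compound 1 `Cc1ccc(-c2cnc(N(Cc3ccccc3)Cc3ccc(C(=O)NO)cc3)s2)cc1` gives the lower of the two numbers measured so far: in a functional assay on PC-3 cells (Homo sapiens) for antiproliferative activity, read by MTT assay, with a stated time of 48 h (a higher number here means a weaker inhibitor of growth, a lower number a stronger inhibitor of growth), compound 1 gives 10400 nM, while compound 2 `CCCCCCCCN(Cc1ccc(C(=O)NO)cc1)c1ncc(-c2ccc(C)cc2)s1` gives 13300 nM. The step of a 1.3-fold higher number from compound 1 to compound 2 (0.11 log units; within the scatter) stays within the scatter. Compound 3 `Cc1ccc(-c2cnc(N(CCCOc3ccccc3)Cc3ccc(C(=O)NO)cc3)s2)cc1` differs from compound 1 by 2-phenoxyethyl in place of phenyl on a saturated chain carbon bound to a nitrogen on an aromatic ring. Within the data shown here, the only measured step, a 1.3-fold higher number from compound 1 to compound 2 (0.11 log units; within the scatter), changes the same place and moved little, so no step beyond the scatter is expected here either. Compound 3 is therefore expected to give about 10400 nM, within 5000 nM to 22000 nM, meaning a step of no change at the digits printed from compound 1 to compound 3 (within the scatter).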

Compound 3, concentration for 50% growth inhibition: 17500 nM
For compound 3 the middle estimate is 1.7-fold (0.23 log units) below the measured one; measured number inside the range.
By their numbers in this assay, from the lowest: compounds 1, 2 and 3 (each within the scatter of the next).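

In this assay, replacing phenyl with 2-phenoxyethyl gives a 1.7-fold higher number from compound 1 to compound 3 (0.23 log units; within the scatter), and phenoxy in place of pentyl gives a 1.3-fold higher number from compound 2 to compound 3 (0.12 log units; within the scatter). This position, on a saturated chain carbon bound to a nitrogen on an aromatic ring, has now carried an arm with an oxygen and a second aromatic ring as well as the phenyl and heptyl groups, and every step remains within the scatter. Nothing available bears on why these numbers stay so close. The compounds shown leave open whether an amine or a carboxylic acid at the end of this arm, or a group as small as methyl, would give a step beyond the scatter.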